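The compounds below may be only part of what the source reports. "The series", "measured", "known", "first", "only" and "open" are said of these compounds alone.

Compound 1, `O=c1c(-c2nn[nH]n2)c[nH]c2c(Br)cccc12`, gives in a functional assay on the whole organism (strain Sprague-Dawley) for inhibition, with Rattus norvegicus as the target (a higher number here means that more compound is needed for the effect, a lower number that less compound is needed), only a limit of the assay, > 5 mg/kg.
Compound 2, `O=c1c(-c2nn[nH]n2)c[nH]c2ccccc12`, gives in this assay 1.25 mg/kg.
Compound 3, `CC(C)c1cccc2c(=O)c(-c3nn[nH]n3)c[nH]c12`, gives in this assay 1.25 mg/kg.

Compound 3 stands level with compound 2, since there is no change at the digits printed from compound 2 to compound 3 (within the scatter). Both differ from compound 1, where the value is a limit, by at least a clear margin: an at least 4.0-fold lower number from compound 1 to compound 2 (0.60 log units; beyond the scatter) and an at least 4.0-fold lower number from compound 1 to compound 3 (0.60 log units; beyond the scatter). That compound 1 reaches only the limit is recorded as the limit of > 5 mg/kg in this assay, at which 1 of the 3 values shown sits.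

Compound 4, `CSc1cccc2c(=O)c(-c3nn[nH]n3)c[nH]c12`, has not been measured. It differs from compound 3 in one place: methylsulfanyl in place of isopropyl on an aromatic carbon. Among the measured compounds shown here, the only measured step that bears on this position without touching compound 1 is the one from hydrogen to isopropyl, which produced no change at the digits printed from compound 2 to compound 3 (within the scatter), so a change at this aromatic carbon among the measured compounds has not shifted the read-out beyond the scatter. For the measured compounds named here, no compound carrying methylsulfanyl has been measured, so the expectation for compound 4 rests on that one step alone. Compound 4 is therefore expected to show no step beyond the scatter, no change at the digits printed from compound 3 to compound 4 (within the scatter). The estimate for compound 4 in this assay is 1.25 mg/kg, with a range from 0.6 mg/kg to 2.5 mg/kg.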

Compound 4, minimum effective dose: 10 mg/kg
Compound 4: the middle estimate sits 8.0-fold (0.90 log units) below what was measured, outside the stated range (above it).
By their numbers in this assay, from the lowest: compounds 2 and 3 (each within the scatter of the next); then compound 4.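

The position turns out not to be indifferent to the group it carries: in this assay, methylsulfanyl in place of isopropyl gives an 8.0-fold higher number from compound 3 to compound 4 (0.90 log units; beyond the scatter), although hydrogen and isopropyl had stood level at this aromatic carbon. Against hydrogen, the same group gives an 8.0-fold higher number from compound 2 to compound 4 (0.90 log units; beyond the scatter), so more compound is needed with methylsulfanyl than with either of those two groups. The shift comes from this one change on the shared core, which shows that the level values of compound 2 and compound 3 did not extend to every group placed on this carbon, though the numbers give no reason for the shift.

Still open, as far as these compounds go, is whether a methoxy group, an amine or a longer chain such as ethylsulfanyl at this carbon would stand with compound 2 and compound 3 or with compound 4. The step from compound 1 to compound 4 cannot be read, and bromo and methylsulfanyl cannot be ordered against each other, because the value of compound 1 is a limit: the limit of > 5 mg/kg in this assay, at which 1 of the 4 values shown sits.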